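Indole carboxamide series: ring-nitrogen substituent change, clearance outlook

The source may hold more compounds than are shown below. What is called first, only, known or untested is meant among the compounds shown, and "the series" means these compounds.

Two members of the series have been measured in an ADME assay on cells (Hepatocyte, Rattus norvegicus) for metabolic stability; a lower number here means slower removal, a higher number faster removal of the compound. Compound 1 `Cc1ccc2[nH]c(C(=O)N[C@H]3CN(S(=O)(=O)c4ccnnc4)C[C@@H]3C(=O)NCCN(C)C)cc2c1` gives 2 uL/min in this assay. Compound 2 `Cc1ccc2[nH]c(C(=O)N[C@H]3CCN(S(=O)(=O)C4CC4)C[C@@H]3C(=O)NCCN(C)C)cc2c1` gives 7 uL/min in this assay, the higher of the two numbers; the gap between compound 2 and compound 1 is beyond the usual scatter, though the two differ in more than one place, so no single structural step accounts for it.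

Compound 3 `Cc1ccc2[nH]c(C(=O)N[C@H]3CCN(C(=O)c4cccnc4)C[C@@H]3C(=O)NCCN(C)C)cc2c1` has not yet been measured in this assay. It differs from compound 2 as follows: (pyridin-3-yl)carbonyl in place of cyclopropylsulfonyl on an amine nitrogen in a ring

For the measured compounds named here, with no single-point step between measured compounds available, the expectation for compound 3 rests on the two values alone, and the change is expected to move the number in this assay only modestly, if at all, in the faster direction: compound 3 is estimated at 10 uL/min in this assay, within a range of 4 uL/min to 25 uL/min, which amounts to an expected step of a 1.4-fold higher number from compound 2 to compound 3 (0.15 log units; within the scatter).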

Compound 3, intrinsic clearance in a liver preparation (reported as CLH), per the amount of preparation that the assay uses: 6 uL/min
Compound 3: middle estimate off by 1.7-fold (0.22 log units), on the high side, within the range that was stated.
By their numbers in this assay, from the lowest: compound 1; then compounds 3 and 2 (each within the scatter of the next).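

In this assay the series now has its first comparison that differs in one place, a 1.2-fold lower number from compound 2 to compound 3 (0.07 log units; within the scatter) on exchanging cyclopropylsulfonyl for (pyridin-3-yl)carbonyl on the amine nitrogen in the six-membered ring. At this position, both the sulfonyl link and the three-membered carbon ring can give way to a carbonyl link and a six-membered aromatic ring, and the two compounds remain indistinguishable in this read-out. Nothing on hand offers an explanation for this result.

Open, from the compounds shown here alone, is how an acetyl group, a longer alkyl chain or a benzenesulfonyl group on the same nitrogen would read in this assay. The gap between compound 1 and compound 2 also remains unassigned to any single place.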